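The source may report more compounds than this note shows. Statements on the series, on what has been measured and on what is new or still open speak of the compounds shown alone.

Measured so far:
compound 1, `C=C(C)[C@@H]1CC=C(C)/C(=N/NC(=O)Nc2nnc(-c3ccc([N+](=O)[O-])cc3)o2)C1`: 300 mg/kg
compound 2, `C=C(C)[C@@H]1CC=C(C)/C(=N/NC(=O)Nc2nnc(-c3ccc(F)cc3)o2)C1`: 300 mg/kg

In a functional assay on the whole organism (strain Wistar) with Rattus norvegicus as the target, with a stated time of 4 h (a higher number here means that more compound is needed for the effect, a lower number that less compound is needed), compound 1 gives 300 mg/kg, and in the same assay compound 2 gives 300 mg/kg. Going by the values given here, the single step between measured compounds, no change at the digits printed from compound 1 to compound 2 (within the scatter), shows that exchanging one substituent on an aromatic carbon for another left the minimum effective dose unchanged. Compound 2 therefore stands level with compound 1 within the scatter; neither can be called the more potent.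

Compound 3, `C=C(C)[C@@H]1CC=C(C)/C(=N/NC(=O)Nc2nnc(-c3ccc(O)cc3)o2)C1`, differs from compound 2 in one place: hydroxy in place of fluoro on an aromatic carbon. Among the compounds with values here, no measured step exchanges fluoro for hydroxy, so the only step that bears on this change is no change at the digits printed from compound 1 to compound 2 (within the scatter), which was flat. On that basis the step of no change at the digits printed from compound 2 to compound 3 (within the scatter) is expected to be none beyond the scatter. Compound 3 is estimated at 300 mg/kg in this assay, with a range from 150 mg/kg to 600 mg/kg.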

Compound 3, minimum effective dose: 300 mg/kg
For compound 3 middle estimate and measured number coincide at the digits printed, and the stated range covers the measured number.
By their numbers in this assay, from the lowest: compounds 1, 2 and 3 (each within the scatter of the next).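

Read in this assay the hydroxy group on an aromatic carbon para to a large group, which adds a hydrogen-bond donor and a hydrogen-bond acceptor that fluoro does not have, gives no change at the digits printed from compound 2 to compound 3 (within the scatter) for the 4-fluorophenyl to 4-hydroxyphenyl exchange. Against nitro, the same hydroxy group gives no change at the digits printed from compound 1 to compound 3 (within the scatter) at this place. The earlier pair offered a single exchange, whereas nitro, fluoro and hydroxy now stand level in all three pairings, so the read-out separates none of these three substituents. No supporting measurement bears on this flat result.

From the compounds shown here alone, whether an amine, a carboxylic acid or a longer alkyl chain at this place would hold the same level remains open. Also open, going by these compounds, is whether any exchange here can move the dose away from this level, since the shared core stays the same across all three compounds.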